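Trifluoromethylphenyl acyl in place of methoxycarbonylmethyl acyl

The source may hold more compounds than are shown below. What is called first, only, known or untested is meant among the compounds shown, and "the series" means these compounds.

The series shares one core, carried by compound 1 `CN1CCN(c2ccc(C3=NN(C(=O)c4ccc(C(F)(F)F)cc4)C(c4ccc(N(C)C)cc4)C3)cc2)CC1`, compound 2 `CC(=O)N1N=C(c2ccc(-n3cncn3)cc2)CC1c1ccc(N(C)C)cc1` and compound 3 `COC(=O)CC(=O)N1N=C(c2ccc(-n3cncn3)cc2)CC1c1ccc(N(C)C)cc1`. In a functional assay on MDA-MB-231 cells (Homo sapiens) for inhibition, read by sulforhodamine B assay, tested at 10 uM (a lower number here means less inhibition, a higher number more inhibition at the concentration tested (going by the name of the read-out)), compound 1 gives 55.4%, compound 2 gives 7.4% and compound 3 gives 6.8%. Compound 3 therefore stands at the lowest of the three numbers, with compound 2 nearest and compound 1 furthest away.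

Among the compounds with values here, the one measured step that changes a single place, a number 0.6 percentage points lower from compound 2 to compound 3 (within the scatter), concerns the acyl group on the ring nitrogen and is small.

Compound 4 `CN(C)c1ccc(C2CC(c3ccc(-n4cncn4)cc3)=NN2C(=O)c2ccc(C(F)(F)F)cc2)cc1` is reached from compound 3 by the change (4-(trifluoromethyl)phenyl in place of (methoxycarbonyl)methyl on a carbonyl carbon). Within the data shown here, no measured step bears on exactly this change. Compound 1 carries the same 4-(trifluoromethyl)phenyl on the carbonyl carbon and reaches 55.4% in this assay, but it differs from compound 4 elsewhere in the molecule as well, so its number is only a hint, not a step.

On that hint alone, compound 4 is expected to rise, with the estimated step of a number 28.2 percentage points higher from compound 3 to compound 4 (beyond the scatter). The estimate for compound 4 in this assay is 35%, with a range from 8% to 62%.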

Compound 4, a percentage reported as inhibition, at one concentration (the size of the read-out at that concentration, not a potency): 16.7%
The estimate for compound 4 lay 18.3 percentage points above the measured number; the range from low to high includes it.
By their numbers in this assay, from the lowest: compounds 3, 2 and 4 (each within the scatter of the next); then compound 1.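

On the carbonyl carbon, the acyl groups now compared are methyl, (methoxycarbonyl)methyl and 4-(trifluoromethyl)phenyl, and in this assay neither step to the aromatic group leaves the scatter (a number 9.9 percentage points higher from compound 3 to compound 4 (within the scatter); a number 9.3 percentage points higher from compound 2 to compound 4 (within the scatter)). This position therefore shows no measurable response to the exchange in these compounds, even though a six-membered aromatic ring enters in place of a chain. The large difference appears at the other place, on the aromatic carbon, where 1H-1,2,4-triazol-1-yl stands in place of 4-methylpiperazin-1-yl with the acyl group held constant (a number 38.7 percentage points lower from compound 1 to compound 4 (beyond the scatter)), and nothing available here accounts for either result.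

Within the data shown here, only this one pair speaks to the exchange on the aromatic carbon, so it remains open whether 4-methylpiperazin-1-yl would give a similar step alongside the methyl acyl group of compound 2 or the (methoxycarbonyl)methyl acyl group of compound 3. Also open, from the compounds shown here alone, is how a carboxylic acid in place of the methyl ester on the acyl chain, or a morpholine on the aromatic carbon, would read in this assay.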